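The source may report more compounds than this note shows. Statements on the series, on what has been measured and on what is new or still open speak of the compounds shown alone.

Measured in a functional assay on MCF7 cells (Homo sapiens) for inhibition, read by MTT assay, with a stated time of 72 h; a higher number here means a weaker inhibitor, a lower number a stronger inhibitor:
- compound 1 `COc1cc2c(Oc3ccc(NC(=O)c4nn(-c5ccccc5C)ccc4=O)cc3)ccnc2cc1OCCCCCC(=O)NO`: 4360 nM
- compound 2 `COc1cc2c(Oc3ccc(NC(=O)c4nn(-c5ccccc5)cc(C)c4=O)cc3F)ccnc2cc1OCCCCCC(=O)NO`: 2330 nM
- compound 3 `COc1cc2c(Oc3ccc(NC(=O)c4nn(-c5ccc(Cl)c(C(F)(F)F)c5)cc(C)c4=O)cc3)ccnc2cc1OCC(=O)NO`: 3480 nM

The three values lie within the scatter of one another, so compound 2 at 2330 nM cannot be separated from compound 1 or compound 3 in this assay.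

The next compound is compound 4 `COc1cc2c(Oc3ccc(NC(=O)c4nn(-c5ccccc5)cc(C)c4=O)cc3F)ccnc2cc1OCCCC(=O)NO`. Its change from compound 2 is hydroxycarbamoyl in place of 2-(hydroxycarbamoyl)ethyl on a saturated chain carbon, three bonds along the chain from an oxygen on an aromatic ring. Cut one bond further out, the same difference reads 5-(hydroxycarbamoyl)pentyl to 3-(hydroxycarbamoyl)propyl.

Among the compounds with values here, no pair of measured compounds isolates this change, so the expectation rests on indirect evidence. Compound 3 carries (hydroxycarbamoyl)methyl and differs elsewhere too, yet compound 3 gives 3480 nM, within the scatter of compound 2. Compound 1 carries 5-(hydroxycarbamoyl)pentyl and gives 4360 nM. These values give no sign of a large dependence on this chain, so no step beyond the scatter is expected.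

The expected step is a 1.3-fold higher number from compound 2 to compound 4 (0.11 log units; within the scatter).

For compound 4 the estimated value is 3000 nM, with an expected range of 1300 nM to 7000 nM.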

Compound 4, half-maximal inhibitory concentration: 1900 nM
Beside the measured number, compound 4's estimate is 1.6-fold (0.20 log units) above it; the range from low to high includes it.
By their numbers in this assay, from the lowest: compounds 4, 2, 3 and 1 (each within the scatter of the next, the first and the last beyond it).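

Within the data shown here, this gives the first direct reading of the chain: with the rest of the structure held fixed, 3-(hydroxycarbamoyl)propyl in place of 5-(hydroxycarbamoyl)pentyl gives a 1.2-fold lower number from compound 2 to compound 4 (0.09 log units; within the scatter) in this assay. Earlier, chain length could only be viewed across compounds that also differed elsewhere, whereas this pair shows that the two chain lengths cannot be told apart in this assay. No supporting measurement bears on why the read-out stays within the scatter across this change.

On these data alone, the effect of (hydroxycarbamoyl)methyl remains open on the exact structure of compound 4, since compound 3 carries that group but differs elsewhere too. Also open, as far as these compounds go, is whether a carboxylic acid or a primary amide at the chain end would keep the number in the same range as the hydroxycarbamoyl group.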